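Cyclohexyl for 2-fluorophenyl on the hydroxyacyl side chain

This account rests on a few compounds, and the source may have more. Where it says the series, first, only, none or still open, it means among the compounds named here.

Of the compounds shown here, three sharing the chloro-tetrazolylbenzylamide core have been measured in a functional assay on a cell-free system (plasma, Homo sapiens), with a stated time of 3 min; a lower number here means a stronger inhibitor, a higher number a weaker inhibitor. Compound 1 `O=C(NCc1cc(Cl)ccc1-n1cnnn1)[C@@H]1CC=NN1C(=O)[C@H](O)c1ccccc1F` gives 1100 nM and stands level with compound 3 `CC(C)(C)C[C@@H](O)C(=O)N1OCC[C@H]1C(=O)NCc1cc(Cl)ccc1-n1cnnn1`, which gives 1100 nM; together they carry the highest of the three numbers. Compound 2 `COC(C)(C)[C@@H](O)C(=O)N1C[C@H]2C[C@H]2[C@H]1C(=O)NCc1cc(Cl)ccc1-n1cnnn1` gives 1000 nM, within the scatter of both. For the measured compounds named here, no pair of measured compounds differs in only one place, so no single step is available to anchor the next change. Compound 4 `O=C(NCc1cc(Cl)ccc1-n1cnnn1)[C@@H]1CC=NN1C(=O)[C@H](O)C1CCCCC1` differs from compound 1 by cyclohexyl in place of 2-fluorophenyl on a saturated chain carbon bound to a carbonyl carbon and an oxygen on a saturated carbon. Going by the values given here, with no comparable step to rest on, the expectation for compound 4 in this assay is a step from compound 1 of a 1.1-fold higher number from compound 1 to compound 4 (0.04 log units; within the scatter), not beyond the scatter. Compound 4 is estimated at 1200 nM, within 400 nM to 4000 nM.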

Compound 4, half-maximal inhibitory concentration: 970 nM
For compound 4 the middle estimate is 1.2-fold (0.09 log units) above the measured one; the measured number falls inside the stated range.
By their numbers in this assay, from the lowest: compounds 4, 2, 1 and 3 (each within the scatter of the next).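

In this assay, for the compounds shown here, cyclohexyl in place of 2-fluorophenyl on the saturated chain carbon gives a 1.1-fold lower number from compound 1 to compound 4 (0.05 log units; within the scatter), the first single-place comparison. At this level of activity, neither the aromatic ring nor the fluorine is required at this position. No measurement on hand accounts for the two groups reading alike.

Open, on these data alone, is whether an amine, a carboxylic acid or a longer chain at this position would move the number beyond the scatter. Also open, as far as these compounds go, is whether the same exchange holds on the cores of compound 2 and compound 3.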